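Hydrogen in place of one methoxy on compound 1

The compounds below may be only part of what the source reports. "The series", "measured", "known", "first", "only" and "open" are said of these compounds alone.

In a functional assay (CEM-VLB cells, Homo sapiens) for antiproliferative activity, read by sulforhodamine B assay, with a stated time of 48 h (on this read-out higher numbers stand for weaker inhibition and lower numbers for stronger inhibition), compound 1 `COc1cc(NS(=O)(=O)c2ccc(N3CCNC3=O)cc2)cc(OC)c1OC` gives > 250 nM, which is a limit of the assay and not a number. Any step from compound 1 therefore has no firm starting value. Compound 4 `COc1cc(NS(=O)(=O)c2ccc(N3CCNC3=O)cc2)cc(OC)c1` carries hydrogen in place of methoxy on an aromatic carbon, ortho to two methoxy groups and para to a large group (hydrogen in place of methoxy on an aromatic carbon).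

Two relatives have numbers: compound 2 `O=C1NCCN1c1ccc(S(=O)(=O)Nc2cccc(Br)c2)cc1` gives 250 nM and compound 3 `Cc1cc(C)cc(NS(=O)(=O)c2ccc(N3CCNC3=O)cc2)c1` gives 400 nM. Within the data shown here, the only measured step, a 1.6-fold higher number from compound 2 to compound 3 (0.20 log units; within the scatter), is 3,5-dimethylphenyl in place of 3-bromophenyl on a sulfonamide nitrogen. It involves no methoxy group, so it bears on the change only indirectly, yet this exchange of groups stayed within the scatter.

A similar outcome is expected in this assay, with no shift beyond the scatter. The estimated step is a step that the limit leaves unreadable from compound 1 to compound 4. Compound 4 is expected at 350 nM, with an estimated range of 150 nM to 800 nM.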

Compound 4, half-maximal inhibitory concentration: 1010 nM
Compound 4: the middle estimate sits 2.9-fold (0.46 log units) below what was measured; measured number outside the range, above it.
By their numbers in this assay, from the lowest: compounds 2 and 3 (each within the scatter of the next); then compound 4.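

No step can be read from compound 1 to compound 4, because compound 1 stands at a limit of the assay and not at a number: the limit of > 250 nM in this assay, at which 1 of the 4 values shown sits.

The compounds shown leave open whether hydrogen in place of methoxy on an aromatic carbon shifts the number in this assay at all, and in which direction.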